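The compounds below may be only part of what the source reports. "The series", "measured", "known", "first", "only" and "open" are said of these compounds alone.

In a functional assay on MDA-MB-231 cells (Homo sapiens) for antiproliferative activity, with a stated time of 4 days (a lower number here means a stronger inhibitor, a higher number a weaker inhibitor), compound 2 `CCCCc1ccc2[nH]c(-c3ccc(OC)cc3)c(C=O)c2c1` gives 6.7 nM and is the strongest inhibitor of the three measured compounds. Compound 3 `COc1ccc(-c2[nH]c3ccc(CC(C)C)cc3c2C=O)cc1` gives 72 nM and compound 1 `COc1ccc(-c2[nH]c3ccc(OC)cc3c2C=O)cc1` gives 260 nM on the same read-out.

Compound 4 `CCCCc1ccc2[nH]c(-c3ccc(C(F)(F)F)cc3)c(C=O)c2c1` keeps the butyl group of compound 2 and carries trifluoromethyl in place of methoxy on an aromatic carbon, para to a large group (trifluoromethyl in place of methoxy on an aromatic carbon).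

The measured steps bear on this change only indirectly. The first is a 39-fold lower number from compound 1 to compound 2 (1.59 log units; beyond the scatter) and is large, the second is a 3.6-fold lower number from compound 1 to compound 3 (0.56 log units; beyond the scatter) and is modest, and the third is an 11-fold higher number from compound 2 to compound 3 (1.03 log units; beyond the scatter) and is also large. All three lie at a different place from the new change, and methoxy is present in all three compounds. They show that one change can move the number a long way in this series, but they give no direction for this replacement.

With compound 2 already at 6.7 nM and no measured replacement of its methoxy group, a modest to large step towards a higher number is expected in this assay as a matter of judgement. The expected change is a 7.5-fold higher number from compound 2 to compound 4 (0.87 log units; beyond the scatter) on this reading. For compound 4 the estimated value is 50 nM with an expected range from 10 nM to 300 nM as the working figure.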

Compound 4, half-maximal inhibitory concentration: 33 nM
Compound 4: the middle estimate sits 1.5-fold (0.18 log units) above what was measured; low and high end bracket the measured number.
By their numbers in this assay, from the lowest: compound 2; then compound 4; then compound 3; then compound 1.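

For the compounds shown here, replacing methoxy with trifluoromethyl, on an aromatic carbon para to a large group, gives the first reading at this position with the butyl group held fixed: in this assay the change gives a 4.9-fold higher number from compound 2 to compound 4 (0.69 log units; beyond the scatter) and so this position does respond to the group it carries. The response is smaller than a 39-fold lower number from compound 1 to compound 2 (1.59 log units; beyond the scatter) at the place of the butyl group, and compound 4 still gives 33 nM without methoxy, with the hydrogen-bond acceptor counted for methoxy gone and more heavy atoms in the entering group. No measurement shown here accounts for the size or direction of this step.

Open at this position is how other groups, such as a hydroxyl, an amine, a nitrile or a carboxylic acid, would compare with methoxy and trifluoromethyl when the butyl group stays in place. Also open, on these data alone, is whether the same replacement gives a step of similar size alongside the isobutyl group of compound 3 or the second methoxy of compound 1, and how a chain longer than butyl would read with either group.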